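Chloro in place of methyl: step from compound 3 to compound 4

A few compounds are considered here, and "the series" means these few. Any claim that something is new, unique, unknown or untested is made for them only; others in the source may bear on it.

Of the compounds shown here, three have been measured in an ADME assay on isolated protein for inhibition of Amine oxidase [flavin-containing] B (Homo sapiens); on this read-out higher numbers stand for weaker inhibition and lower numbers for stronger inhibition. Compound 1 `C#CCNC1CCc2c(SCCc3ccc(Br)cc3)cccc21` gives 1250 nM, compound 2 `C#CCNC1CCc2c(SCCc3cccc(C)c3)cccc21` gives 4960 nM, and compound 3 `C#CCNC1CCc2c(SCCc3ccc(C)cc3)cccc21` gives 4520 nM. On these numbers compound 3 stands second highest of the three; the gap to compound 2 is within the scatter, as the step of a 1.1-fold lower number from compound 2 to compound 3 (0.04 log units; within the scatter) shows, while the step of a 3.6-fold higher number from compound 1 to compound 3 (0.56 log units; beyond the scatter) lies beyond it.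

Compound 4 `C#CCNC1CCc2c(SCCc3ccc(Cl)cc3)cccc21` has not yet been measured. It differs from compound 3 by chloro in place of methyl on an aromatic carbon. The step that bears on this is the exchange of bromo for methyl on the same aromatic carbon, a 3.6-fold higher number from compound 1 to compound 3 (0.56 log units; beyond the scatter), a modest rise beyond the scatter. The steps of a 4.0-fold higher number from compound 1 to compound 2 (0.60 log units; beyond the scatter) and a 1.1-fold lower number from compound 2 to compound 3 (0.04 log units; within the scatter) move the methyl rather than replace it and bear only indirectly. Chloro is, like bromo, a halogen, so a drop in this assay is expected. The step of a 2.5-fold lower number from compound 3 to compound 4 (0.40 log units; beyond the scatter) is estimated at somewhat less than the full bromo-to-methyl difference. Compound 4 is therefore expected to give about 1800 nM in this assay, with a range of 900 nM to 3600 nM.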

Compound 4, half-maximal inhibitory concentration: 920 nM
Estimate against measurement, compound 4: 2.0-fold (0.29 log units) above; measured number inside the range.
By their numbers in this assay, from the lowest: compounds 4 and 1 (each within the scatter of the next); then compounds 3 and 2 (each within the scatter of the next).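

In this assay, chloro on this aromatic carbon lands with bromo rather than with methyl: replacing methyl gives a clear drop (a 4.9-fold lower number from compound 3 to compound 4 (0.69 log units; beyond the scatter)), and the 4-chlorophenyl compound also stands apart from the 3-methylphenyl one (a 5.4-fold lower number from compound 2 to compound 4 (0.73 log units; beyond the scatter)). Chloro and bromo are not told apart at this position (a 1.4-fold lower number from compound 1 to compound 4 (0.13 log units; within the scatter)), so the exchange between these two halogens changes little here. Across the four compounds, both halogen compounds sit on the low side and both methyl compounds on the high side, and no compound goes against this.

No measurement shown accounts for this split between halogens and methyl. From the compounds shown here alone, whether fluoro, methoxy or trifluoromethyl on the same carbon would fall with the halogens or with methyl remains open, as does whether a chloro on another carbon of this ring would keep the low number.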